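The source may hold more compounds than are shown below. What is called first, only, known or untested is meant among the compounds shown, and "the series" means these compounds.

Compound 1 `CCCCc1ccc2[nH]c(-c3ccc(CC)cc3)c(C=O)c2c1`: 27 nM
Compound 2 `CCCCc1ccc2[nH]c(-c3ccc(OC)cc3)c(/C=N/NC(=O)c3ccc(F)cc3)c2c1`: 19 nM

In a functional assay on MDA-MB-231 cells (Homo sapiens) for antiproliferative activity, with a stated time of 4 days (a lower number here means a stronger inhibitor, a higher number a weaker inhibitor), compound 2 gives 19 nM and compound 1 gives 27 nM, so the two values lie within the usual scatter of each other. Compound 3 `CCCCc1ccc2[nH]c(-c3ccc(OC)cc3)c(/C=N/NC(=O)c3cccc(O)c3)c2c1` keeps the structure of compound 2 except for one change: 3-hydroxyphenyl in place of 4-fluorophenyl on a carbonyl carbon, with 3-hydroxyphenyl in place of 4-fluorophenyl on a carbonyl carbon. Among the compounds with values here, no measured pair shows this change alone, so the expectation is uncertain. A small move towards weaker inhibition in this assay is expected, possibly no larger than the scatter. The expected step is a 1.6-fold higher number from compound 2 to compound 3 (0.20 log units; within the scatter). Compound 3 is estimated at 30 nM, with an expected range of 10 nM to 100 nM.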

Compound 3, half-maximal inhibitory concentration: 30 nM
Compound 3: middle estimate and measured number agree at the digits printed; low and high end bracket the measured number.
By their numbers in this assay, from the lowest: compounds 2, 1 and 3 (each within the scatter of the next).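

In this assay the first direct test of this position, on a carbonyl carbon, gives a 1.6-fold higher number from compound 2 to compound 3 (0.20 log units; within the scatter). So 4-fluorophenyl and 3-hydroxyphenyl, which differ in their counts of hydrogen-bond donors and acceptors, cannot be told apart here, and this position accepts both without a readable difference in antiproliferative activity. As far as these compounds go, whether that holds for 4-hydroxyphenyl, 3-fluorophenyl, or a ring bearing an amine or a carboxylic acid stays open. Nothing measured here explains why the two numbers stay so close.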